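The compounds below may be only part of what the source reports. "The series", "measured", "known", "first", "only" and "open" are said of these compounds alone.

Working notes on the series around the shared core of compound 1 (`O=C1CCCCC/C1=C\c1cccc(Cl)c1`), read in a functional assay on CCRF-CEM cells (Homo sapiens) for inhibition; a higher number here means a weaker inhibitor, a lower number a stronger inhibitor. Compound 1 gives 40500 nM, compound 2 (`O=C1CCCCC/C1=C\c1cccc(Br)c1`) gives 137000 nM, and compound 3 (`COc1cccc(/C=C2\CCCCCC2=O)c1`) gives 128000 nM. Compound 3 stands with compound 2 at the high end of these three numbers, and the two cannot be separated: a 1.1-fold lower number from compound 2 to compound 3 (0.03 log units; within the scatter). Compound 1 lies clear of it, with a 3.2-fold higher number from compound 1 to compound 3 (0.50 log units; beyond the scatter).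

The next change leads to compound 4 (`O=C1CCCCC/C1=C\c1cccc([N+](=O)[O-])c1`): nitro in place of methoxy on an aromatic carbon. In words, this is nitro in place of methoxy on an aromatic carbon. Among the compounds with values here, no measured step involves nitro, so the only guide is the other exchanges of one group on an aromatic carbon. Those are a 3.4-fold higher number from compound 1 to compound 2 (0.53 log units; beyond the scatter) and the methoxy step from chloro given above, both modest, while the exchange of bromo for methoxy stayed within the scatter. A step of similar modest size or smaller is therefore expected in this assay. With compound 3 at the high end of the spread, the expectation leans towards a lower number. The estimated step is a 1.7-fold lower number from compound 3 to compound 4 (0.23 log units; within the scatter). Compound 4 is expected at 75000 nM, with an estimated range of 30000 nM to 180000 nM.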

Compound 4, half-maximal inhibitory concentration: 30100 nM
The estimate for compound 4 lay 2.5-fold (0.40 log units) above the measured number, within the range that was stated.
By their numbers in this assay, from the lowest: compounds 4 and 1 (each within the scatter of the next); then compounds 3 and 2 (each within the scatter of the next).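

In this assay, nitro on this aromatic carbon falls on the low side of the series, with a 4.3-fold lower number from compound 3 to compound 4 (0.63 log units; beyond the scatter) and a 4.6-fold lower number from compound 2 to compound 4 (0.66 log units; beyond the scatter), so exchanging methoxy or bromo for nitro gives a modest step beyond the scatter. Against chloro there is no such separation, with a 1.3-fold lower number from compound 1 to compound 4 (0.13 log units; within the scatter), so compound 1 no longer stands alone at the low end, and the four compounds now form two groups, nitro with chloro and methoxy with bromo, each pair inseparable within itself. Nothing available bears on why the groups divide in this way.

Going by these compounds, whether an amine, a carboxylic acid or a nitrile at this place would join the low pair, the high pair or neither remains open, as does whether any group here can reach a number clearly below those of compound 1 and compound 4. Also open, on these data alone, is whether the same division holds with these groups elsewhere on the aromatic ring, or with a change in the shared core.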